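A Trifluoromethyl Swap in a Series at Its Limit

The source may report more compounds than this note shows. Statements on the series, on what has been measured and on what is new or still open speak of the compounds shown alone.

Measured so far in a functional assay on Raji cells (Homo sapiens) for cytotoxicity, with a stated time of 72 h; on this read-out higher numbers stand for an effect only at larger amounts of compound and lower numbers for an effect already at smaller amounts:
- compound 1 `CC(C)=CCC[C@](C)(/C=C/c1ccc(O)cc1)/C=C/c1cccc(F)c1` gives > 26000 nM (a limit)
- compound 2 `C=C[C@@](C)(/C=C/c1ccc(Nc2ccccc2)cc1)CCC=C(C)C` gives > 26000 nM (a limit)
- compound 3 `C=C[C@@](C)(/C=C/c1ccc(Nc2cccc(OC(F)(F)F)c2)cc1)CCC=C(C)C` gives > 26000 nM (a limit)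

None of these is a true number, and the whole set rests on (the limit of > 26000 nM in this assay, at which 3 of the 3 values shown sit). Compound 3 therefore has no exact place in the series. Compound 4 `C=C[C@@](C)(/C=C/c1ccc(Nc2cccc(C(F)(F)F)c2)cc1)CCC=C(C)C` carries trifluoromethyl in place of trifluoromethoxy on an aromatic carbon, meta to a large group (trifluoromethyl in place of trifluoromethoxy on an aromatic carbon). Among the compounds with values here, the one measured step that bears on this position is a step that the two limits leave unreadable from compound 2 to compound 3, where trifluoromethoxy replaced hydrogen on an aromatic carbon. It gives no size to carry forward. Compound 4 is expected to show no change beyond the usual scatter in this assay, on the evidence of compound 3 with > 26000 nM. The expected step, with no firm direction, is a number no higher from compound 3 to compound 4 (the limit leaves the size open). For compound 4 the estimated value is 26000 nM, with an expected range from 12000 nM to 52000 nM.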

Compound 4, half-maximal effective concentration: > 26000 nM
Compound 4: no number, only a limit (the forecaster's own chance of this, stated with the estimate: 85%); the middle value lies on the limit itself.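

The steps among compound 2, compound 3 and compound 4 cannot be read in this assay, as each of these compounds gives only a limit and not a number. The compounds shown leave open whether trifluoromethyl, trifluoromethoxy or hydrogen at this place makes any difference to the effect, with no exact value to settle it: the limit of > 26000 nM in this assay, at which 4 of the 4 values shown sit.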